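Swapping sec-butyl for cyclopropyl: expecting little change

The source may hold more compounds than are shown below. What is called first, only, known or untested is meant among the compounds shown, and "the series" means these compounds.

Measured so far:
compound 1 `CC(C)(C)C/N=C(\NC#N)Nc1ccncc1` gives 5 mg/kg in a functional assay on the whole organism (blood, strain Wistar-Okamoto) with Rattus norvegicus as the target, with a stated time of 5 days; a lower number here means that less compound is needed, a higher number that more compound is needed for the effect
compound 2 `CCC(C)C(C)/N=C(\NC#N)Nc1ccncc1` gives 8 mg/kg in this assay

Among the compounds with values here, compound 2 holds the higher of the two numbers, yet its only neighbour, compound 1, is within the scatter: a 1.6-fold higher number from compound 1 to compound 2 (0.20 log units; within the scatter). Compound 3 `CC(/N=C(\NC#N)Nc1ccncc1)C1CC1` is not yet measured. It differs from compound 2 by cyclopropyl in place of sec-butyl on a saturated chain carbon bound to a double-bonded nitrogen and a saturated chain carbon. Within the data shown here, the single step known, from compound 1 to compound 2, also exchanged one small alkyl group on the same part of the molecule for another and stayed within the scatter, so no step beyond the scatter is expected here: no change at the digits printed from compound 2 to compound 3 (within the scatter). Compound 3 is therefore estimated at 8 mg/kg, ranging from 3 mg/kg to 20 mg/kg.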

Compound 3, minimum effective dose: 3 mg/kg
Beside the measured number, compound 3's estimate is 2.7-fold (0.43 log units) above it; low and high end bracket the measured number.
By their numbers in this assay, from the lowest: compounds 3, 1 and 2 (each within the scatter of the next, the first and the last beyond it).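

Within this assay, this position turns out to respond to a small exchange: cyclopropyl in place of sec-butyl gives a 2.7-fold lower number from compound 2 to compound 3 (0.43 log units; beyond the scatter), the first step here to pass beyond the scatter. Replacing neopentyl with 1-cyclopropylethyl gives a 1.7-fold lower number from compound 1 to compound 3 (0.22 log units; within the scatter), so the ring-bearing group cannot be told apart from neopentyl. Nothing available explains the difference between cyclopropyl and sec-butyl. As far as these compounds go, whether this response is specific to cyclopropyl remains open. A cyclobutyl ring or a longer chain at this place could show how far it extends.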